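Propylsulfonyl in Place of Ethyl on Compound 3

The compounds below may be only part of what the source reports. "The series", "measured", "known", "first", "only" and "open" are said of these compounds alone.

Measured in a functional assay (aorta) with Oryctolagus cuniculus as the target; on this read-out lower numbers stand for stronger inhibition and higher numbers for weaker inhibition:
Compound 1, `OCc1ccc(-c2nn(Cc3c(F)cccc3F)c3ccccc23)o1`, gives 15000 nM.
Compound 2, `OCc1ccc(-c2nn(Cc3cccnc3)c3ccccc23)o1`, gives 9600 nM.
Compound 3, `CCc1cnc(-c2nn(Cc3ccccc3F)c3ncccc23)nc1N`, gives 272000 nM.

Compound 3 stands highest of the three numbers in this assay. Compound 1 gives 15000 nM and compound 2 gives 9600 nM, both well apart from compound 3 beyond the scatter.

Compound 4, `CCCS(=O)(=O)c1cnc(-c2nn(Cc3ccccc3F)c3ncccc23)nc1N`, differs from compound 3 by propylsulfonyl in place of ethyl on an aromatic carbon. For the measured compounds named here, the only measured step, a 1.6-fold lower number from compound 1 to compound 2 (0.19 log units; within the scatter), concerns a different place on a different core, and no measured pair touches the ethyl group or its position. The data therefore give no ground for a step in either direction, and the expectation for compound 4 is a change within the scatter, a 1.1-fold lower number from compound 3 to compound 4 (0.04 log units; within the scatter). Compound 4 is estimated at 250000 nM, with a range of 60000 nM to 1000000 nM.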

Compound 4, half-maximal inhibitory concentration: 378000 nM
Compound 4: middle estimate off by 1.5-fold (0.18 log units), on the low side; low and high end bracket the measured number.
By their numbers in this assay, from the lowest: compounds 2 and 1 (each within the scatter of the next); then compounds 3 and 4 (each within the scatter of the next).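

In this assay, propylsulfonyl in place of ethyl on this aromatic carbon, ortho to an amino group, gives a 1.4-fold higher number from compound 3 to compound 4 (0.14 log units; within the scatter). This position therefore accepts a change from a two-carbon ethyl group to a sulfonyl-bearing chain with two hydrogen-bond acceptors, with no shift beyond the scatter. Nothing available explains this result.

From the compounds shown here alone, what an amine or a carboxylic acid on this carbon would do to the number remains open. So does whether a longer sulfonyl chain would leave it within the scatter.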